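The source may hold more compounds than are shown below. What is called first, only, known or untested is meant among the compounds shown, and "the series" means these compounds.

In a functional assay on DU-145 cells (Homo sapiens) for inhibition, read by trypan blue exclusion, with a stated time of 96 h (on this read-out lower numbers stand for stronger inhibition of growth and higher numbers for weaker inhibition of growth), compound 1, `COc1ccccc1/C=C(/SCc1ccc(Cl)cc1)C(=O)c1ccc([N+](=O)[O-])cc1`, gives 10000 nM, the higher of the two exact numbers available. Compound 2, `COc1ccccc1/C=C(/SCc1ccc(Cl)cc1)C(=O)c1ccc(Cl)cc1`, gives 1000 nM. Compound 3, `O=C(/C(=C\c1c(O)cc(O)cc1O)S(=O)(=O)c1ccc(Br)cc1)c1ccc(Cl)cc1`, gives > 100000 nM, which is a limit of the assay and not a number.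

The account now turns from compound 1 to compound 4, `Cc1ccsc1/C=C(/SCc1ccc(Cl)cc1)C(=O)c1ccc([N+](=O)[O-])cc1`, which has not yet been measured in this assay. The structural change is 3-methylthiophen-2-yl in place of 2-methoxyphenyl on a double-bonded chain carbon bound to a double-bonded chain carbon.

Among the measured compounds shown here, no measured step tests this change directly. The only one available is a 10-fold lower number from compound 1 to compound 2 (1.00 log units; beyond the scatter), a modest step beyond the scatter that comes from chloro in place of nitro on an aromatic carbon. Compound 4 keeps the nitro group of compound 1, so that step shows only that this series can respond to a single substitution. It gives neither a size nor a direction for the present exchange.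

With no measured guide, no shift beyond the scatter is expected in this assay, though the uncertainty is wide. The expected change is a 1.3-fold lower number from compound 1 to compound 4 (0.10 log units; within the scatter). For compound 4, the estimated value is 8000 nM, within an expected range of 2000 nM to 35000 nM.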

Compound 4, concentration for 50% growth inhibition: > 100000 nM
Compound 4 gave a limit, no number (the forecaster's own chance of this, stated with the estimate: 10%); at least 12-fold (1.09 log units) between middle value and limit.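

The exchange of 2-methoxyphenyl for 3-methylthiophen-2-yl gives an at least 10-fold higher number from compound 1 to compound 4 (1.00 log units; beyond the scatter) in this assay. Until now, only the exchange of nitro for chloro on an aromatic carbon had been seen to move the number, so this result shows that the group on a double-bonded chain carbon bound to a double-bonded chain carbon also matters, and that this change goes toward weaker inhibition of growth. Compound 4 gives > 100000 nM, which is a limit of the assay and not a number, so the step has a lower bound but no fixed size: the limit of > 100000 nM in this assay, at which 2 of the 4 values shown sit.

The compounds shown leave open whether an unsubstituted phenyl or a thiophen-2-yl without the methyl would, at this place, stay near compound 1 or also reach the limit. They also leave open whether 3-methylthiophen-2-yl would have the same effect in the chloro compound, compound 2, since the exchange is shown only with the nitro group in place.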